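The compounds below may be only part of what the source reports. "The series", "measured", "known", "first", "only" and "open" are said of these compounds alone.

Compound 1, `CC[C@H](N)C(=O)N[C@@H]1C(=O)N2[C@@H](CC[C@@H]1CCNC(=O)NCc1ccccc1)CC[C@H]2C(=O)NC(c1ccccc1)c1ccccc1`, in a functional assay on PC-3 cells (Homo sapiens) for cytotoxicity, read by MTT assay, with a stated time of 96 h (a higher number here means a weaker inhibitor, a lower number a stronger inhibitor), gives > 100000 nM, which is a limit of the assay and not a number.
Compound 2, `CC[C@H](NC)C(=O)N[C@@H]1C(=O)N2[C@@H](CC[C@@H]1CCNC(=O)NCc1ccccc1)CC[C@H]2C(=O)NC(c1ccccc1)c1ccccc1`, in this assay gives 83500 nM.
Compound 3, `CCNCC[C@H]1CC[C@H]2CC[C@@H](C(=O)NC(c3ccccc3)c3ccccc3)N2C(=O)[C@H]1NC(=O)[C@@H](N)CC`, in this assay gives > 100000 nM, again a limit of the assay rather than a number.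

Two of the three values sit at the same ceiling, (the limit of > 100000 nM in this assay, at which 2 of the 3 values shown sit), so the measured series is nearly flat. Going by the values given here, the one readable comparison is the change (methyl in place of hydrogen on an amine nitrogen), which gave an at least 1.1-fold lower number from compound 1 to compound 2 (0.07 log units; that floor lies within the scatter). The cores of compound 1 and compound 3 differ by ethyl in place of benzylcarbamoyl on an amine nitrogen, and a step that the two limits leave unreadable from compound 1 to compound 3.

Compound 4, `CCNCC[C@H]1CC[C@H]2CC[C@@H](C(=O)NC(c3ccccc3)c3ccccc3)N2C(=O)[C@H]1NC(=O)[C@H](CC)NC`, is not yet measured. It differs from compound 3 by methyl in place of hydrogen on an amine nitrogen, the same change as from compound 1 to compound 2, at a place described in identical words. The step from compound 1 to compound 2 was at most a small gain, and compound 3 itself sits at the limit, so compound 4 is expected to stay near that ceiling: the estimated step is a number no higher from compound 3 to compound 4 (the limit leaves the size open). The expected value for compound 4 in this assay is 100000 nM, within roughly 40000 nM to 300000 nM, and quite possibly reported only as a limit.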

Compound 4, half-maximal inhibitory concentration: > 100000 nM
Compound 4 gave a limit, no number (the forecaster's own chance of this, stated with the estimate: 60%); the middle value lies on the limit itself.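

In this assay compound 4 gives > 100000 nM, which is a limit of the assay and not a number. Ethyl in place of benzylcarbamoyl on an amine nitrogen gave an at least 1.1-fold higher number from compound 2 to compound 4 (0.07 log units; that floor lies within the scatter), so this comparison does not separate the two cores. Methyl in place of hydrogen on an amine nitrogen, carried from the core of compound 1 to the core of compound 3, yields steps that cannot be read wherever both ends are limits, so the result neither shows that the change carries over nor shows that it fails to, and the series remains pressed against a single ceiling: the limit of > 100000 nM in this assay, at which 3 of the 4 values shown sit.

The compounds shown leave open whether a longer chain such as propyl, or a cyclopropyl group, on that amine nitrogen would bring a value clear of the ceiling. They also leave open what the methyl change does in a core whose unmethylated compound gives a number rather than a limit.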